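Aryl sulfone in place of benzyl sulfone on a shared core

A few compounds are considered here, and "the series" means these few. Any claim that something is new, unique, unknown or untested is made for them only; others in the source may bear on it.

Compound 1 `Cn1c(=O)c(S(=O)(=O)Cc2ccc(F)cc2F)cc2cnc(Nc3ccc4[nH]ccc4c3)nc21`: 1000 nM
Compound 2 `COc1ccc(Nc2ncc3cc(S(=O)(=O)c4ccc(Cl)cc4)c(=O)n(C)c3n2)cc1`: 15000 nM
Compound 3 `Cn1c(=O)c(S(=O)(=O)c2ccc(F)cc2F)cc2cnc(Nc3ccc4cc[nH]c4c3)nc21`: 5000 nM

Of the compounds shown here, three have been measured in a functional assay on K562 cells (Homo sapiens) for inhibition, read by trypan blue exclusion, with a stated time of 72 h; on this read-out lower numbers stand for stronger inhibition and higher numbers for weaker inhibition. Compound 1 stands lowest of the three numbers. Its nearest neighbour is compound 3, whose value is higher by a margin beyond the scatter, and furthest away is compound 2, also beyond the scatter. Going by the values given here, no two of the measured compounds differ in a single place, so no step between them can be read directly.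

Compound 4 `Cn1c(=O)c(S(=O)(=O)c2ccc(Br)cc2)cc2cnc(Nc3ccc4[nH]ccc4c3)nc21` has not been measured. It differs from compound 1 in one place: 4-bromophenyl in place of 2,4-difluorobenzyl on a sulfonyl sulfur. Compound 3 carries a group of the same kind on the sulfonyl sulfur, and compound 2 another, and both give higher numbers than compound 1 in this assay, although each also differs from compound 1 elsewhere. On that basis the step is expected to move upward, toward a weaker inhibition, by a size of a 3.0-fold higher number from compound 1 to compound 4 (0.48 log units; beyond the scatter). Compound 4 is therefore estimated to give 3000 nM in this assay, within a range from 1000 nM to 10000 nM.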

Compound 4, half-maximal inhibitory concentration: 5000 nM
Compound 4: the middle estimate sits 1.7-fold (0.22 log units) below what was measured; the measured number falls inside the stated range.
By their numbers in this assay, from the lowest: compound 1; then compounds 3 and 4 (each within the scatter of the next); then compound 2.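

Replacing 2,4-difluorobenzyl with 4-bromophenyl on the sulfonyl sulfur, with the rest of the molecule unchanged, gives in this assay a 5.0-fold higher number from compound 1 to compound 4 (0.70 log units; beyond the scatter). Going by these compounds alone, this is the first direct reading of this position alone, as compound 2 and compound 3 each also differ from compound 1 elsewhere. The change replaces a benzyl with a phenyl and two fluorines with one bromine at once, and no evidence at hand separates these two parts or offers a reason for the step.

Still open, going by these compounds, is whether 4-bromobenzyl on the same core would show which part of the change matters. Also open, on these data alone, is whether a longer chain on the sulfonyl sulfur, or an amine on its aromatic ring, would give a number lower than that of compound 1.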